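Lengthening the chain end: from compound 2 to compound 3

The source may hold more compounds than are shown below. What is called first, only, known or untested is meant among the compounds shown, and "the series" means these compounds.

Measured so far:
Compound 1, `CCCCC/C=C/CCCCCCCCCC1(C(=O)OC)CO1`, gives 10 mg/kg
Compound 2, `CCCCCCCCCCCC1(C(=O)OC)CO1`, gives 10 mg/kg

In a functional assay on the whole organism with Rattus norvegicus as the target, in the glucose tolerance test (a higher number here means that more compound is needed for the effect, a lower number that less compound is needed), compound 2 gives 10 mg/kg, and it stands level with compound 1, which gives 10 mg/kg. Among the compounds with values here, only one measured step bears on the question of chain length, and it is no change at the digits printed from compound 1 to compound 2 (within the scatter). There, a long unsaturated end of the chain was cut back to ethyl, and the dose needed did not move beyond the scatter.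

Compound 3, `CCCCCCCCCCCCCCC1(C(=O)OC)CO1`, differs from compound 2 by propyl in place of hydrogen on a saturated chain carbon, ten or more bonds along the chain from a saturated ring carbon. This is a change at the same end of the chain, now in the direction of lengthening rather than shortening. Within the data shown here, since the one step that touches the chain end, no change at the digits printed from compound 1 to compound 2 (within the scatter), showed no change, the expectation is that adding propyl will likewise leave the dose where it is, though no measured compound shows a chain of exactly this length.

Compound 3 is therefore estimated to give 10 mg/kg, with a range from 4 mg/kg to 25 mg/kg. The expected step is no change at the digits printed from compound 2 to compound 3 (within the scatter), none beyond the scatter.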

Compound 3, minimum effective dose: 4 mg/kg
Compound 3: the middle estimate sits 2.5-fold (0.40 log units) above what was measured; the measured number falls inside the stated range.
By their numbers in this assay, from the lowest: compound 3; then compounds 1 and 2 (each within the scatter of the next).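

The chain end does affect the dose in this assay: propyl in place of hydrogen on a saturated chain carbon, ten or more bonds along the chain from a saturated ring carbon, gives a 2.5-fold lower number from compound 2 to compound 3 (0.40 log units; beyond the scatter), whereas ethyl in place of hept-1-en-1-yl gave no change at the digits printed from compound 1 to compound 2 (within the scatter). Pentyl in place of hept-1-en-1-yl, on a saturated chain carbon nine bonds along the chain from a saturated ring carbon, gives a 2.5-fold lower number from compound 1 to compound 3 (0.40 log units; beyond the scatter), although this change alters both the length of the end group and its double bond, so the two effects cannot be separated. The three compounds do not support a simple rule that a longer chain lowers the dose, since compound 1, with the longest chain, stands level with compound 2, with the shortest, and only compound 3 stands apart.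

Nothing shown explains why the dose responds in this way to the chain end. Going by these compounds, it remains open whether a longer saturated chain than that of compound 3 would lower the dose further or lose the gain, and whether a carboxylic acid in place of the methyl ester would keep it.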